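Swapping Phenoxymethyl for (4-Chlorophenyl)amino on the Carbonyl

The compounds below may be only part of what the source reports. "The series", "measured", "known", "first", "only" and "open" are said of these compounds alone.

Of the compounds shown here, two built on a shared core have so far been tested in a functional assay on cells (Lymphocyte); a higher number here means a weaker inhibitor, a lower number a stronger inhibitor. Compound 1 `O=C(O)c1nc(N2CCN(C(=O)COc3ccc(Cl)cc3)CC2)c2cc(F)sc2n1` reaches only a limit of this assay, > 10000 nM, and no number. Compound 2 `Nc1nc(N2CCN(C(=O)COc3ccccc3)CC2)c2ccsc2n1` gives 780 nM in this assay. Among the measured compounds shown here, that is the only plain number so far; the one other value is a limit, (the limit of > 10000 nM in this assay, at which 1 of the 2 values shown sits), so compound 2 cannot be ranked against anything yet.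

Compound 3 `Nc1nc(N2CCN(C(=O)Nc3ccc(Cl)cc3)CC2)c2ccsc2n1` differs from compound 2 in a single place: (4-chlorophenyl)amino in place of phenoxymethyl on a carbonyl carbon. For the measured compounds named here, no pair of measured compounds differs in just one place, so the size of this step cannot be read from the data and has to be expected instead. The step expected from compound 2 to compound 3 is a 1.3-fold lower number from compound 2 to compound 3 (0.11 log units; within the scatter), which is no more than the usual scatter. Compound 3 is therefore estimated at 600 nM, with a likely range from 150 nM to 2500 nM.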

Compound 3, half-maximal inhibitory concentration: 6700 nM
Compound 3: middle estimate off by 11-fold (1.05 log units), on the low side, outside the stated range (above it).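

Putting (4-chlorophenyl)amino in place of phenoxymethyl on this carbonyl carbon gives an 8.6-fold higher number from compound 2 to compound 3 (0.93 log units; beyond the scatter) in this assay, which makes compound 2 the stronger inhibitor of this pair. This first readable step shows that activity responds to the group at this position, even though the two groups match in heavy atoms and each carries one six-membered aromatic ring. Nothing measured here explains what drives the step.

Going by these compounds, the change brings in both the chlorine and the amide hydrogen, so which of them matters stays open, and a plain phenylamino group on this carbonyl carbon would help to separate the two. On these data alone, it also remains open how a smaller group, such as a simple alkylamine, or a longer chain would fare at this position.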